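A few compounds are considered here, and "the series" means these few. Any claim that something is new, unique, unknown or untested is made for them only; others in the source may bear on it.

Compound 1 `CC(C)=CCC/C(C)=C/CC/C(C)=C/CC[C@@H]1[C@@]2(C)CC/C(=N\OCc3cn(-c4c(Cl)cc([N+](=O)[O-])cc4Cl)nn3)C(C)(C)[C@@H]2CC[C@@]1(C)O`: 16400 nM
Compound 2 `COc1cccc(-n2cc(COc3ccc(/C=C4\C[C@]5(C)[C@@H](CC/C=C(\C)CC/C=C(\C)CCC=C(C)C)[C@](C)(O)CC[C@H]5C(C)(C)C4=O)cc3)nn2)c1`: 14500 nM

Both compounds were tested in a functional assay on DU-145 cells (Homo sapiens) for cytotoxicity, read by MTT assay, with a stated time of 48 h; a lower number here means a stronger inhibitor, a higher number a weaker inhibitor. Compound 2 gives 14500 nM and compound 1 gives 16400 nM. These two numbers lie within the normal scatter of repeated measurements, so neither compound can be ranked above the other.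

Compound 3 `CC(C)=CCC/C(C)=C/CC/C(C)=C/CC[C@@H]1[C@@]2(C)C/C(=C\c3ccc(OCc4cn(-c5ccccc5C#N)nn4)cc3)C(=O)C(C)(C)[C@@H]2CC[C@@]1(C)O` is built from compound 2 by a single exchange of one aromatic group for another: 2-cyanophenyl in place of 3-methoxyphenyl on an aromatic nitrogen. The group that enters has the same size by heavy-atom count as the group that leaves, but it carries a nitrile instead of a methoxy group.

For the measured compounds named here, no pair of measured compounds differing in just one place is available, so the data do not show how far a single exchange can move the number in this assay. With no measured guide to size or direction, no shift beyond the scatter is expected. The estimated step of a 1.0-fold lower number from compound 2 to compound 3 (0.02 log units; within the scatter) is therefore small. For compound 3, the expected value is 14000 nM, with an estimated range from 6000 nM to 30000 nM.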

Compound 3, half-maximal inhibitory concentration: 25100 nM
Compound 3: middle estimate off by 1.8-fold (0.25 log units), on the low side; measured number inside the range.
By their numbers in this assay, from the lowest: compounds 2, 1 and 3 (each within the scatter of the next).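

For the compounds shown here, this is the first exchange here that changes only one place, the group on an aromatic nitrogen of the five-membered ring with 3 nitrogen, while the rest of the molecule stays the same. In this assay putting 2-cyanophenyl in place of 3-methoxyphenyl gives a 1.7-fold higher number from compound 2 to compound 3 (0.24 log units; within the scatter) and so shows that this particular swap, between two groups of equal heavy-atom count, cannot be told apart from repeat-to-repeat variation in the measurement. Nothing available explains the result or tests what the two groups do in the cells.

The two groups differ both in the substituent, nitrile against methoxy, and in the number of its place on the ring, so this single step cannot separate those two changes; 3-cyanophenyl or 2-methoxyphenyl would be needed to pull them apart. The compounds shown also leave open whether a group of a different kind at this nitrogen, such as an aminophenyl ring, a phenyl ring bearing a carboxylic acid or a longer alkyl chain, would move the number beyond the scatter.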